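A Thiophene in Place of Fluorophenyl: Expected Activity

This account rests on a few compounds, and the source may have more. Where it says the series, first, only, none or still open, it means among the compounds named here.

Three compounds have been measured in a functional assay on SW-620 cells (Homo sapiens) for antiproliferative activity, read by MTT assay, with a stated time of 24 h; on this read-out higher numbers stand for weaker inhibition and lower numbers for stronger inhibition:

Compound 1, `COc1ccc(C(=O)/C=C/c2cc(OC)c(OC)c(OC)c2)c2c1C=CC(C)(C)O2`, gives 9150 nM.
Compound 2, `COc1ccc(C(=O)/C=C/c2ccc(F)cc2)c2c1C=CC(C)(C)O2`, gives only a limit, > 10000 nM.
Compound 3, `COc1ccc(C(=O)/C=C/c2ccc3ccccc3n2)c2c1C=CC(C)(C)O2`, gives 2250 nM.

Compound 2 is the weakest point of the set as far as the numbers go: its result is the limit of > 10000 nM in this assay, at which 1 of the 3 values shown sits, so no number is known for it, only that it lies past the highest concentration tested. Compound 1 and compound 3 both give real numbers, and compound 3 sits at the lower, more active end of what has been seen.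

The next compound, compound 4, `COc1ccc(C(=O)/C=C/c2cccs2)c2c1C=CC(C)(C)O2`, differs from compound 2 in a single exchange: thiophen-2-yl in place of 4-fluorophenyl on a double-bonded chain carbon bound to a double-bonded chain carbon. The shared core and the double-bonded chain are unchanged.

Among the measured compounds shown here, no measured pair in this set shares this kind of exchange, so there is no direct guide to its size. Since compound 2 offers only a limit, the move from compound 2 to compound 4 is expected to be an at least 1.2-fold lower number from compound 2 to compound 4 (0.09 log units; that floor lies within the scatter), a change of modest size toward the active side, but not beyond what the scatter of the other measured compounds would allow. Compound 4 is therefore expected to give about 8000 nM, with a plausible range from 3000 nM to 20000 nM, and a real chance that only a limit is again reported.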

Compound 4, half-maximal inhibitory concentration: > 10000 nM
Compound 4 gave a limit, no number; the forecaster's own chance of this, stated with the estimate: 45%; middle value at least 1.2-fold (0.09 log units) from the limit.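

Among the compounds shown here, compound 2 and compound 4 both give only a limit, not a number, in this assay, so no step between them can be read. The compounds shown leave open how far past that limit each of the two lies, and whether thiophen-2-yl in place of 4-fluorophenyl changes the activity at all.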